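Ester variation on the fluoropyridine amide series

The source may report more compounds than this note shows. Statements on the series, on what has been measured and on what is new or still open speak of the compounds shown alone.

Compound 1 `CC(C)OCCOC(=O)c1cccc(-c2cc(C(=O)Nc3ccncc3F)ccc2CN)c1` gives 37 nM in an assay on isolated protein for inhibition of Rho-associated protein kinase 2 (Homo sapiens), read by radiometric assay (on this read-out higher numbers stand for weaker inhibition and lower numbers for stronger inhibition), the highest of the three numbers at hand. Compound 3 `CCCCCOC(=O)c1cccc(-c2cc(C(=O)Nc3ccncc3)ccc2CN)c1` gives 4.9 nM in this assay, and compound 2 `CC(N)c1ccc(C(=O)Nc2ccncc2)cc1-c1ccc(F)cc1` gives 1.2 nM; each differs from compound 1 in more than one place, so no single change can be read from these gaps. Compound 4 `NCc1ccc(C(=O)Nc2ccncc2F)cc1-c1cccc(C(=O)OCC2CCCC2)c1` is the next member to be measured. It differs from compound 1 by cyclopentyl in place of isopropoxymethyl on a saturated chain carbon bound to an oxygen next to a carbonyl group. Within the data shown here, no measured pair differs only at this position, so the size of the step is open. A modest move toward a lower number is expected for compound 4, a 1.9-fold lower number from compound 1 to compound 4 (0.27 log units; within the scatter). The expectation rests on compound 3, whose ester chain carries no oxygen and which gives 4.9 nM in this assay, though it also lacks the fluorine of compound 1. For compound 4 the estimate is 20 nM, within 6 nM to 70 nM.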

Compound 4, half-maximal inhibitory concentration: 13 nM
The estimate for compound 4 lay 1.5-fold (0.19 log units) above the measured number; measured number inside the range.
By their numbers in this assay, from the lowest: compound 2; then compound 3; then compound 4; then compound 1.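

In this assay, cyclopentyl in place of isopropoxymethyl on a saturated chain carbon bound to an oxygen next to a carbonyl group gives a 2.8-fold lower number from compound 1 to compound 4 (0.45 log units; beyond the scatter) as the first single-place step read at this position. The position therefore accepts a five-membered ring of carbon only, and the number falls when the chain loses its oxygen. Nothing at hand accounts for this step.

Among these compounds, the single pair does not separate loss of the oxygen from gain of the ring. On these data alone, a carboxylic acid or an amine on this ester position remains open.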